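Cyclohexyloxy replacing isobutyl on the carbonyl carbon

This account rests on a few compounds, and the source may have more. Where it says the series, first, only, none or still open, it means among the compounds named here.

Compound 1 `CC1=C(C(=O)CC(C)C)C(c2ccco2)NC(=O)N1` gives 16% in an assay on membranes from CHO cells for displacement of a labelled ligand from adenosine receptor A1 (Homo sapiens), read by scintillation counting, with a stated time of 60 min, tested at 1 uM; on this read-out higher numbers stand for more inhibition at the one concentration tested (going by the name of the read-out) and lower numbers for less inhibition. Compound 2 `CC1=C(C(=O)CC(C)C)C(c2cccs2)NC(=O)N1` gives 19% in this assay, and the step of a number 3 percentage points higher from compound 1 to compound 2 (within the scatter) shows that compound 2 and compound 1 lie within the scatter of each other; neither number can be ordered ahead of the other.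

Compound 3 `CC1=C(C(=O)OC2CCCCC2)C(c2cccs2)NC(=O)N1` differs from compound 2 by cyclohexyloxy in place of isobutyl on a carbonyl carbon. Among the compounds with values here, the single measured step, thiophen-2-yl in place of furan-2-yl on a saturated ring carbon, leaves the group on the carbonyl carbon untouched, so it does not bear on this change; no measured pair varies the carbonyl substituent. Within the data shown here, with no relevant step, no movement in this assay beyond the scatter is expected in either direction, and the uncertainty is wide.

Compound 3 is therefore estimated at 20% in this assay, with a range from 5% to 42%. The expected step is a number 1 percentage points higher from compound 2 to compound 3 (within the scatter).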

Compound 3, a percentage reported as inhibition, at one concentration (the size of the read-out at that concentration, not a potency): 7%
Compound 3: the middle estimate sits 13 percentage points above what was measured; the range from low to high includes it.
By their numbers in this assay, from the lowest: compounds 3, 1 and 2 (each within the scatter of the next, the first and the last beyond it).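

In this assay, within the data shown here, the group on the carbonyl carbon is the first place where a change moves the number beyond the scatter: cyclohexyloxy in place of isobutyl gives a number 12 percentage points lower from compound 2 to compound 3 (beyond the scatter) and counts as a modest step. Among these compounds, the only earlier step, thiophen-2-yl in place of furan-2-yl on a saturated ring carbon, gave a number 3 percentage points higher from compound 1 to compound 2 (within the scatter) and so showed no such movement. Nothing measured on these compounds accounts for the step on the carbonyl carbon.

The entering group brings its oxygen and its six-membered ring together, so the step cannot be assigned to either one. Going by these compounds, an ethoxy group or a cyclohexyl group on the carbonyl carbon would separate the two, and whether the step carries over to the furan-2-yl compounds remains open.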